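Dimethoxypyrimidinyl sulfonamide on a trifluoromethylquinoline thiourea scaffold

This account rests on a few compounds, and the source may have more. Where it says the series, first, only, none or still open, it means among the compounds named here.

The series shares a thiourea linking a trifluoromethyl-bearing quinoline to a benzenesulfonamide, and differs only in the group on the sulfonamide nitrogen. Compound 1 `CC(=O)NS(=O)(=O)c1ccc(N/C(S)=N\c2ccnc3cc(C(F)(F)F)ccc23)cc1` carries an acetyl there; in a functional assay on HepG2 cells (Homo sapiens) for antiproliferative activity, read by sulforhodamine B assay, with a stated time of 48 h (a higher number here means a weaker inhibitor, a lower number a stronger inhibitor), compound 1 gives 28400 nM. Compound 2 `O=S(=O)(Nc1ccccn1)c1ccc(N/C(S)=N\c2ccnc3cc(C(F)(F)F)ccc23)cc1` carries a pyridin-2-yl, and in this assay compound 2 gives 28000 nM; the step of a 1.0-fold lower number from compound 1 to compound 2 (0.01 log units; within the scatter) is within the scatter, so exchanging one sulfonamide substituent for another leaves the number unchanged here. Compound 3 `Cc1ccnc(NS(=O)(=O)c2ccc(N/C(S)=N\c3ccnc4cc(C(F)(F)F)ccc34)cc2)n1` carries a 4-methylpyrimidin-2-yl, and in this assay compound 3 is reported as "not active" (no number reported), with no number attached, so it stands outside the range the other two define and cannot be placed against them.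

Compound 4 `COc1cc(NS(=O)(=O)c2ccc(N/C(S)=N\c3ccnc4cc(C(F)(F)F)ccc34)cc2)nc(OC)n1` differs from compound 3 by 2,6-dimethoxypyrimidin-4-yl in place of 4-methylpyrimidin-2-yl on a sulfonamide nitrogen. Within the data shown here, no measured step covers this change; the only step, from compound 1 to compound 2, concerns smaller substituents and was flat. Two compounds sit near the same weak value and compound 3 gave no number, so compound 4 is expected to remain weak, possibly again without a reportable number. In this assay the estimated value for compound 4 is 40000 nM, within 15000 nM to 150000 nM.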

Compound 4, half-maximal inhibitory concentration: 76700 nM
Compound 4: the middle estimate sits 1.9-fold (0.28 log units) below what was measured, within the range that was stated.
By their numbers in this assay, from the lowest: compounds 2 and 1 (each within the scatter of the next); then compound 4.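

The sulfonamide nitrogen, which had looked flat between acetyl and pyridin-2-yl, now shows that a substituent there can shift the number in this assay: 2,6-dimethoxypyrimidin-4-yl gives a 2.7-fold higher number from compound 2 to compound 4 (0.44 log units; beyond the scatter) and a 2.7-fold higher number from compound 1 to compound 4 (0.43 log units; beyond the scatter), both modest steps in the direction of weaker inhibition from two different starting groups. The direct change from 4-methylpyrimidin-2-yl to 2,6-dimethoxypyrimidin-4-yl cannot be read as a step, as compound 3 has only the report "not active", though compound 4 shows that a substituted pyrimidine at this place can still return a number. Nothing available explains why the dimethoxypyrimidinyl group reads differently from the acetyl and pyridin-2-yl groups.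

The compounds shown leave open whether the step belongs to the pyrimidine ring, to its two methoxy groups or to the point at which the ring is attached, as no pair here separates these features. They also leave open how a simple alkyl chain, a primary amine or a carboxylic acid carried on the sulfonamide nitrogen would read, and whether any group at this place can bring the number lower than the values of compound 1 and compound 2.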